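Dropping the Methoxy Group of Compound 1: An Expected Outcome

This account rests on a few compounds, and the source may have more. Where it says the series, first, only, none or still open, it means among the compounds named here.

Among the compounds with values here, compound 1 `COc1ccc(Nc2ncnc3c(=N)n(NC(=O)c4ccccc4)cnc23)cc1` is the one member of this small set for which a number is reported. In an ADME assay on Vero cells (Chlorocebus sabaeus) for cytotoxicity (on this read-out lower numbers stand for an effect already at smaller amounts and higher numbers for an effect only at larger amounts of compound), compound 1 gives 2.12 ug/mL. The two companions carry no number: compound 2 `COc1ccc(Nc2ncnc3c(=N)n(NC(=O)c4ccco4)cnc23)cc1` is entered as "not determined" (no result reported) in this assay, and compound 3 `COc1ccc(Nc2ncnc3c(=N)n(NC(C)=O)cnc23)cc1` likewise as "not determined" (no result reported). Compound 1 therefore stands alone on the numbers shown, and no step between measured compounds can be drawn from this set.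

Compound 4 `N=c1c2ncnc(Nc3ccccc3)c2ncn1NC(=O)c1ccccc1` differs from compound 1 in a single place: hydrogen in place of methoxy on an aromatic carbon, which reads, in short, as hydrogen in place of methoxy on an aromatic carbon, para to a large group. Within the data shown here, nothing in the measured set speaks to the size or direction of such a change; the account rests on the single number of compound 1 and on the change itself.

The step from compound 1 to compound 4 is expected to be small, and is estimated as a 1.2-fold higher number from compound 1 to compound 4 (0.07 log units; within the scatter), a move that is expected to stay within the usual scatter of this assay. For compound 4 the estimated value in this assay is 2.5 ug/mL, with an expected range from 0.8 ug/mL to 8 ug/mL.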

Compound 4, half-maximal effective concentration: 2.35 ug/mL
Compound 4: middle estimate off by 1.1-fold (0.03 log units), on the high side, and the stated range covers the measured number.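

In this assay, hydrogen in place of methoxy on an aromatic carbon, para to a large group, gives a 1.1-fold higher number from compound 1 to compound 4 (0.04 log units; within the scatter) and so leaves the two compounds indistinguishable on this read-out. Within the data shown here, this is the first comparison that the set allows, as the earlier compounds offered a single number and no step between measured compounds. It shows that, with the rest of compound 1 held fixed, the methoxy group at this place can be exchanged for hydrogen without a change that stands clear of the usual scatter of repeated measurements, although no accompanying measurement bears on why this is so.

The compounds shown leave open whether a carboxylic acid, an amine or a longer chain such as butoxy at this same place would also stay within the scatter of compound 1 at 2.12 ug/mL in this assay. They also leave open whether the exchange of methoxy for hydrogen would read the same with the furan-2-carbonyl or acetyl group of compound 2 and compound 3, for which no number is shown.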